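The source may report more compounds than this note shows. Statements on the series, on what has been measured and on what is new or still open speak of the compounds shown alone.

Measured compounds in a functional assay on HeLa cells (Homo sapiens) for antiproliferative activity, read by CCK-8 assay, with a stated time of 72 h; on this read-out lower numbers stand for stronger inhibition of growth and higher numbers for weaker inhibition of growth:
- Compound 1 `CC[C@@H]1C(=O)N(C)c2cnc(Nc3ccc(S(=O)(=O)Nc4ccccc4)cc3)nc2N1C1CCCC1`: 5140 nM
- Compound 2 `CCC1C(=O)N(C)c2cnc(-n3ccc4cc(F)ccc43)nc2N1c1ccn(C)n1`: "not active" (no number reported)
- Compound 3 `CCCCNC(=O)c1ccc2c(ccn2-c2ncc3c(n2)N(C2CCCC2)[C@H](CC)C(=O)N3C)c1`: 346 nM

Compound 2 has no place on the numerical scale of this assay. It was reported only as "not active" (no number reported), whereas compound 1 gives 5140 nM and compound 3 gives 346 nM. Attention now turns to compound 4 `CCC1C(=O)N(C)c2cnc(-n3ccc4cc(C(N)=O)ccc43)nc2N1c1ccn(C)n1`, which has yet to be measured. The structural change is carbamoyl in place of fluoro on an aromatic carbon, with the rest of the structure unchanged.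

Within the data shown here, no step between measured compounds isolates this change, and the absence of a number for compound 2 means that no step from it can be sized. The evidence is thin. A butyl-substituted carbamoyl is also carried by compound 3, which gives 346 nM, but that compound has other structural differences as well. The expected direction is therefore toward stronger inhibition of growth, of a size that cannot be stated, and a second report without a number remains quite possible. Compound 4 is estimated at 2000 nM, with an expected range of 300 nM to 10000 nM.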

Compound 4, concentration for 50% growth inhibition: 27400 nM
Compound 4: middle estimate off by 14-fold (1.14 log units), on the low side, and the stated range ends below it.
By their numbers in this assay, from the lowest: compound 3; then compound 1; then compound 4.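

In this assay, among these compounds, compound 4 gives 27400 nM, but compound 2 has no number, so no step between compound 2 and compound 4 can be read. No supporting evidence bears on this result. The compounds shown leave open how far carbamoyl in place of fluoro, with the rest of the structure unchanged, shifts inhibition of growth.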